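Swapping the Ring Amine on an Adenosine Receptor Ligand

A few compounds are considered here, and "the series" means these few. Any claim that something is new, unique, unknown or untested is made for them only; others in the source may bear on it.

Compound 1 `CN1CCN(c2nc(-c3cc(Cl)ccc3Cl)nc3[nH]cnc23)CC1` and compound 2 `Oc1cccc(-c2nc(N3CCCCC3)c3nc[nH]c3n2)c1` were both tested in an assay on cells for displacement of a labelled ligand from adenosine receptor A3 (Homo sapiens), read by scintillation counting and radioligand binding, with a stated time of 180 min, tested at 10 uM; on this read-out lower numbers stand for less inhibition and higher numbers for more inhibition at the one concentration tested (going by the name of the read-out). In this assay compound 1 reaches the assay limit of > 80%. In this assay compound 2 likewise reaches the assay limit of > 80%. Compound 2 thus stands where every measured value sits, at the limit (the limit of > 80% in this assay, at which 2 of the 2 values shown sit). Compound 3 `CN1CCN(c2nc(-c3cccc(O)c3)nc3[nH]cnc23)CC1` is not yet measured and differs from compound 2 by 4-methylpiperazin-1-yl in place of piperidin-1-yl on an aromatic carbon. Going by the values given here, no measured pair isolates this change, but the entering group already sits on compound 1, which also stands at the limit. The step is expected to stay within the scatter a step that the limit leaves unreadable from compound 2 to compound 3. Compound 3 is expected to give about 85%, between 65% and 95%.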

Compound 3, a percentage reported as inhibition, at one concentration (the size of the read-out at that concentration, not a potency): > 80%
Compound 3 ended at the assay's limit; the forecaster's own chance of this, stated with the estimate: 70%; the middle value lies beyond the limit too.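

The steps among compound 1, compound 2 and compound 3 cannot be read, since each value is a limit, not a number: the limit of > 80% in this assay, at which 3 of the 3 values shown sit. The compounds shown leave open how far their inhibition in this assay truly differs.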